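Shortening the Chain on Compound 3

A few compounds are considered here, and "the series" means these few. Any claim that something is new, unique, unknown or untested is made for them only; others in the source may bear on it.

Of the compounds shown here, three sharing one core have been tested in a functional assay on the whole organism for inhibition, with Mythimna separata as the target, with a stated time of 5 days; a higher number here means that more compound is needed for the effect, a lower number that less compound is needed. Compound 1, `CCCCn1ncc(OCc2nnc(-c3ccccc3)o2)c(Cl)c1=O`, gives > 300 ug/mL in this assay, which is a limit of the assay rather than a number. Compound 2, `CCn1ncc(OCc2nnc(-c3ccccc3)o2)c(Cl)c1=O`, gives > 300 ug/mL, again only a limit. Going by the values given here, compound 3, `CCCCn1ncc(OCc2nnc(-c3ccc(F)cc3)o2)c(Cl)c1=O`, gives 162 ug/mL, the only value that is an actual number. The other two results sit at the limit of > 300 ug/mL in this assay, at which 2 of the 3 values shown sit. Among the compounds with values here, compound 3 therefore stands as the single compound with a readable result. The change from compound 1 to compound 3 was an at least 1.8-fold lower number from compound 1 to compound 3 (0.26 log units; that floor lies within the scatter). The change from compound 1 to compound 2 was a step that the two limits leave unreadable from compound 1 to compound 2.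

Compound 4, `CCn1ncc(OCc2nnc(-c3ccc(F)cc3)o2)c(Cl)c1=O`, has not yet been measured. It differs from compound 3 in one place: hydrogen in place of ethyl on a saturated chain carbon, two bonds along the chain from an aromatic nitrogen. Within the data shown here, the step from compound 1 to compound 2 is the same change on the core without fluoro, and it is unreadable, so no measured step tells how large this change is or in which direction it runs. The fluoro step does not bear on it directly. The step of a 1.4-fold higher number from compound 3 to compound 4 (0.15 log units; within the scatter) is therefore expected to be small, with a wide spread, and a limit instead of a number remains quite possible. Compound 4 is estimated at 230 ug/mL, with a range from 100 ug/mL to 600 ug/mL.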

Compound 4, half-maximal effective concentration: > 300 ug/mL
Compound 4: only a limit was reported; the forecaster's own chance of this, stated with the estimate: 40%; at least 1.3-fold (0.11 log units) between middle value and limit.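

Going by these compounds alone, the change from butyl to ethyl could not be read on the core without fluoro, where both compounds stop at a limit, but with the fluoro group in place it has a direction for the first time: in this assay it gives an at least 1.8-fold higher number from compound 3 to compound 4 (0.26 log units; that floor lies within the scatter). This is only a floor, since compound 4 gives a limit and not a number, and the floor itself lies within the usual scatter, so the result does not establish that butyl and ethyl truly differ. It does show that shortening the chain on compound 3 did not yield a number, and the set now rests mostly on a single limit, while the steps joining two limits cannot be read: the limit of > 300 ug/mL in this assay, at which 3 of the 4 values shown sit.

On these data alone, how far compound 4 really lies from compound 3 stays unknown, and so does whether the fluoro group makes any real difference when the chain is ethyl. Nor do these compounds tell what a longer chain such as hexyl, or a butyl chain ending in an amine or a carboxylic acid, would give in this assay.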